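Shifting Two Fluorines on the Ring-Nitrogen Aryl Group

The source may report more compounds than this note shows. Statements on the series, on what has been measured and on what is new or still open speak of the compounds shown alone.

Compound 1 `Nc1scc(CN2CCN(c3cccc(Cl)c3Cl)CC2)c1C(=O)c1ccc(Cl)cc1` gives 1% in a functional assay on CHO cells with adenosine receptor A1 (Homo sapiens) as the target, read by cAMP accumulation and immunoassay, with a stated time of 6 min, tested at 0.01 uM; a higher number here means a weaker effect of the compound at the concentration tested, a lower number a stronger effect. Compound 2 `Nc1scc(CN2CCN(c3ccc(F)cc3F)CC2)c1C(=O)c1ccc(Cl)cc1`, carrying 2,4-difluorophenyl in place of 2,3-dichlorophenyl on an amine nitrogen in a ring, gives 0%; the step of a number 1 percentage points lower from compound 1 to compound 2 (within the scatter) leaves compound 2 level with compound 1 within the scatter. Compound 3 `Nc1scc(CN2CCN(c3ccc(F)c(F)c3)CC2)c1C(=O)c1ccc(Cl)cc1` differs from compound 2 by 3,4-difluorophenyl in place of 2,4-difluorophenyl on an amine nitrogen in a ring. Going by the values given here, no measured step exchanges one difluorophenyl for another, and the only step that alters this aryl group stayed within the scatter, so nothing beyond the scatter is expected here. Compound 3 is therefore estimated at 1%, between -4% and 8%, an expected step of a number 1 percentage points higher from compound 2 to compound 3 (within the scatter).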

Compound 3, a percentage reported as activity, at one concentration (the size of the read-out at that concentration, not a potency): -3.2%
The estimate for compound 3 lay 4.2 percentage points above the measured number; low and high end bracket the measured number.
By their numbers in this assay, from the lowest: compounds 3, 2 and 1 (each within the scatter of the next).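

Swapping 2,4-difluorophenyl for 3,4-difluorophenyl, which uses the same atoms joined differently, gives a number 3.2 percentage points lower from compound 2 to compound 3 (within the scatter) in this assay. Replacing 2,3-dichlorophenyl with 3,4-difluorophenyl gives a number 4.2 percentage points lower from compound 1 to compound 3 (within the scatter), so these three halogenated aryl groups on the ring nitrogen cannot be told apart at this concentration. No evidence here explains this result.

As far as these compounds go, whether an unsubstituted phenyl, a methoxyphenyl or a pyridyl group at this position would also read level remains open. From the compounds shown here alone, the reading gives the size of the effect at one concentration only, so whether these compounds would show a stronger or weaker effect than one another at other concentrations also remains open.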